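Replacing a Piperazine Side Chain with a Short Alcohol

The source may hold more compounds than are shown below. What is called first, only, known or untested is meant among the compounds shown, and "the series" means these compounds.

Compound 1 `CN1CCN(Cc2cn(Cc3ccc(F)cc3)c3cnc(C(=O)N(C)O)cc23)CC1` was examined in an ADME assay on CEM-SS cells (Homo sapiens) for cytotoxicity, read by XTT assay; on this read-out lower numbers stand for higher toxicity in this test and higher numbers for lower toxicity in this test. Compound 1 returned only the limit > 224000 nM, the end of the tested range rather than a number. Compound 2 `CN(O)C(=O)c1cc2c(CO)cn(Cc3ccc(F)cc3)c2cn1` has also been measured in this assay. Compound 2 likewise returned only the limit > 266000 nM. The step that the two limits leave unreadable from compound 1 to compound 2 therefore cannot be sized, because compound 1 sits at the limit of > 224000 nM in this assay, at which 1 of the 2 values shown sits. Compound 2 sits at the limit of > 266000 nM in this assay, at which 1 of the 2 values shown sits. Compound 3 `CN(O)C(=O)c1cc2c(CCCO)cn(Cc3ccc(F)cc3)c2cn1` is the compound still to be measured. It differs from compound 1 by 2-hydroxyethyl in place of 4-methylpiperazin-1-yl on a saturated chain carbon bound to an aromatic carbon. Going by the values given here, the only measured step that bears on this change is the one from compound 1 to compound 2, and its size is unreadable, so no direction beyond the scatter can be foreseen in this assay, and compound 3 is expected to return a limit again. Compound 3 is estimated at 250000 nM, within a range from 100000 nM to 600000 nM, which would mean an expected step that the limit leaves unreadable from compound 1 to compound 3.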

Compound 3, half-maximal cytotoxic concentration: > 10000 nM
Compound 3 gave a limit, no number; the forecaster's own chance of this, stated with the estimate: 85%; the middle value does not contradict the limit.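

Going by these compounds alone, compound 1, compound 2 and compound 3 each gave only a limit in this assay, not a number, so no step between them can be read. The compounds shown leave open whether their side chains differ in toxicity, and at what concentration any of them harms these cells.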